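The source may report more compounds than this note shows. Statements on the series, on what has been measured and on what is new or still open speak of the compounds shown alone.

Working notes on the fluorophenyl amides of the shared core, tested in a functional assay on KYSE-410 cells (Homo sapiens) for antiproliferative activity, read by MTT assay, with a stated time of 72 h; on this read-out lower numbers stand for stronger inhibition and higher numbers for weaker inhibition. Compound 1 `O=C(Nc1ccc(F)cc1)c1cc(=O)[nH]c2cc(Br)ccc12` gives > 20000 nM, which is a limit of the assay and not a number. Among the compounds with values here, compound 2 `O=C(Nc1cccc(F)c1)c1cc(=O)[nH]c2cc(Br)ccc12` gives 7300 nM, the only true number so far. Compound 3 `O=C(Nc1cc(F)cc(F)c1)c1cc(=O)[nH]c2cc(Br)ccc12` departs from compound 2 by one change: fluoro in place of hydrogen on an aromatic carbon. Within the data shown here, the single measured step, an at least 2.7-fold lower number from compound 1 to compound 2 (0.43 log units; beyond the scatter), shows that the place of the fluoro group can matter in this assay. On these data alone, it rests on (the limit of > 20000 nM in this assay, at which 1 of the 2 values shown sits), so its full size is unknown, and it moves a fluoro group rather than adding one. It therefore bears only loosely here, and no shift beyond the scatter is expected, with no firm direction. The expected change is a 1.2-fold lower number from compound 2 to compound 3 (0.09 log units; within the scatter). Compound 3 is estimated at 6000 nM, with an expected range of 2200 nM to 16000 nM.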

Compound 3, half-maximal inhibitory concentration: 11200 nM
Estimate against measurement, compound 3: 1.9-fold (0.27 log units) below; the range from low to high includes it.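

In this assay, fluoro in place of hydrogen on an aromatic carbon, meta to a fluoro group already on the ring, gives a 1.5-fold higher number from compound 2 to compound 3 (0.19 log units; within the scatter). Within the data shown here, both ends of this step are true numbers, so it is the first step whose full size can be read, and the first that adds a group rather than moving one; at this position, a second fluoro group produces no shift beyond the scatter. Compound 1 remains a limit of the assay, so the full size of the earlier step remains unknown: the limit of > 20000 nM in this assay, at which 1 of the 3 values shown sits.

The compounds shown leave open whether this position tolerates only fluoro or also takes a larger or different group, such as chloro, methoxy or an amine. They also leave open whether any group here, a carboxylic acid included, would shift the number beyond the scatter.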